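From 2-fluorophenyl to 4-fluorophenyl on a shared core

The compounds below may be only part of what the source reports. "The series", "measured", "known", "first", "only" and "open" are said of these compounds alone.

Values measured in a functional assay on DU-145 cells (Homo sapiens) for cytotoxicity, read by sulforhodamine B assay, with a stated time of 48 h (on this read-out higher numbers stand for weaker inhibition and lower numbers for stronger inhibition), are as follows:
- compound 1 `C[C@H]1CC[C@@H]2[C@@H](OC(=O)[C@]23CC(c2ccccc2Br)=NO3)[C@]2(C)C(=O)C=C[C@@]12O` gives 18000 nM
- compound 2 `C[C@H]1CC[C@@H]2[C@@H](OC(=O)[C@]23CC(c2ccc(O)cc2)=NO3)[C@]2(C)C(=O)C=C[C@@]12O` gives 93000 nM
- compound 3 `C[C@H]1CC[C@@H]2[C@@H](OC(=O)[C@]23CC(c2ccccc2F)=NO3)[C@]2(C)C(=O)C=C[C@@]12O` gives 24000 nM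

Compound 3 shows no gap beyond the scatter to its closest neighbour (a 1.3-fold higher number from compound 1 to compound 3 (0.12 log units; within the scatter)) but a clear gap to the remaining compound (a 3.9-fold lower number from compound 2 to compound 3 (0.59 log units; beyond the scatter)). The next compound, compound 4 `C[C@H]1CC[C@@H]2[C@@H](OC(=O)[C@]23CC(c2ccc(F)cc2)=NO3)[C@]2(C)C(=O)C=C[C@@]12O`, has the same atoms joined differently (4-fluorophenyl in place of 2-fluorophenyl on a carbon with a double bond to nitrogen) with 4-fluorophenyl in place of 2-fluorophenyl on a carbon with a double bond to nitrogen.

Among the compounds with values here, no measured pair isolates this kind of change. The closest guide is the swap of fluoro for bromo (a 1.3-fold higher number from compound 1 to compound 3 (0.12 log units; within the scatter)), which stayed small. The larger steps (a 5.2-fold higher number from compound 1 to compound 2 (0.71 log units; beyond the scatter)) involve 4-hydroxyphenyl in compound 2, which has no fluoro, so they say little here. No step beyond the scatter is therefore expected in this assay, and the estimated change is a 1.3-fold higher number from compound 3 to compound 4 (0.10 log units; within the scatter) in size. For compound 4 the expected value is 30000 nM within an estimated range of 13000 nM to 70000 nM for this read-out.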

Compound 4, half-maximal inhibitory concentration: 13000 nM
For compound 4 the middle estimate is 2.3-fold (0.36 log units) above the measured one; measured number inside the range.
By their numbers in this assay, from the lowest: compounds 4, 1 and 3 (each within the scatter of the next); then compound 2.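

In this assay, the 4-fluorophenyl group in place of 2-fluorophenyl leaves the result within the scatter (a 1.8-fold lower number from compound 3 to compound 4 (0.27 log units; within the scatter)), so on this shared core the place of the fluoro on the phenyl ring makes no readable difference. The 4-fluorophenyl group in place of 2-bromophenyl also stays within the scatter (a 1.4-fold lower number from compound 1 to compound 4 (0.14 log units; within the scatter)), which puts compounds 1, 3 and 4 level in this assay. Fluoro in place of hydroxy on the same ring carbon gives the first single-atom comparison with compound 2 (a 7.2-fold lower number from compound 2 to compound 4 (0.85 log units; beyond the scatter)), a step beyond the scatter that sets the hydroxy compound apart from the three halogen compounds.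

From the compounds shown here alone, how a methoxy group or an amine on this phenyl ring would compare remains open. Nothing in the data shown accounts for these steps.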